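Half-life hold as the ring on the carbonyl changes

A few compounds are considered here, and "the series" means these few. Any claim that something is new, unique, unknown or untested is made for them only; others in the source may bear on it.

Of the compounds shown here, three have been measured. Compound 1 `C=CC(=O)N1CC(NC(=O)Cn2c(C)c(C(=O)N3CCc4c(cccc4OC)C3)c3cc(Cl)ccc32)C1` gives 1.67 h in a physicochemical assay for pharmacokinetics, read by LC-MS, in phosphate buffer, at pH 7.4, in the presence of a further agent that is not named here; on this read-out higher numbers stand for a longer-lived compound and lower numbers for a shorter-lived compound. Compound 2 `C=CC(=O)N1CC(NC(=O)Cn2cc(C(=O)N3CCc4c(Cl)cccc4C3)c3cc(Br)ccc32)C1` gives 1.67 h in this assay. Compound 3 `C=CC(=O)N1CC(NC(=O)Cn2cc(C(=O)N3CCc4c(cccc4OC)C3)c3cc(Br)cc(C)c32)C1` gives 1.67 h in this assay. For the measured compounds named here, compound 2 thus stands level with compound 1 and compound 3 at the digits read, the nearest being compound 1 and the furthest compound 3, both within the scatter; no measured pair differs in a single place, so no step between measured compounds is on hand.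

Compound 4 `C=CC(=O)N1CC(NC(=O)Cn2cc(C(=O)N3CCc4cc(F)ccc4C3)c3cc(Br)ccc32)C1` is the next compound awaiting measurement. It differs from compound 2 in one place: a group of 11 heavy atoms (9 carbon, 1 nitrogen, 1 fluorine; one six-membered non-aromatic ring with 1 hetero atom, one six-membered aromatic ring of carbon only) in place of a group of 11 heavy atoms (9 carbon, 1 nitrogen, 1 chlorine; one six-membered non-aromatic ring with 1 hetero atom, one six-membered aromatic ring of carbon only), on a carbonyl carbon. The exchange sits on a carbonyl carbon whose other neighbours are aromatic carbon.

Three compounds with differing substitution all fall at one reading, so no direction is indicated. The step expected no change at the digits printed from compound 2 to compound 4 (within the scatter) is none beyond the scatter. Compound 4 is expected to give 1.67 h in this assay, within a range from 0.9 h to 3.2 h.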

Compound 4, half-life: 1.67 h
The estimate for compound 4 equals the measured number at the digits printed, and the stated range covers the measured number.
By their numbers in this assay, from the lowest: compounds 1, 2, 3 and 4 (each within the scatter of the next).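

In this assay, for the compounds shown here, replacing the chlorine-bearing group on the carbonyl carbon with 6-fluoro-1,2,3,4-tetrahydroisoquinolin-2-yl gives no change at the digits printed from compound 2 to compound 4 (within the scatter), and this is the only step so far that isolates a single place. The half-life reading at this position therefore holds through this one exchange, in which chlorine gives way to fluorine and the heavy-atom count of the group stays the same. No measurement on hand bears on why the reading holds.

On these data alone, it remains open whether the reading would hold with a group on the carbonyl carbon that departs further from these two, such as a piperidin-1-yl ring or a tetrahydroisoquinoline carrying a carboxylic acid or an amine. This single step also leaves open how changes elsewhere on the shared core would read.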